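The compounds below may be only part of what the source reports. "The series", "measured", "known", "first", "only" and "open" are said of these compounds alone.

Measured in a functional assay on MCF7 cells (Homo sapiens) for antiproliferative activity; a higher number here means a weaker inhibitor, a lower number a stronger inhibitor:
- Compound 1 `CC(C)=CCc1cc(C(=O)Nc2cc3ccc(OCCC4CCCCN4)c(C)c3oc2=O)ccc1O`: 710 nM
- Compound 2 `CCN(C)CCCOc1ccc2cc(NC(=O)c3ccc(O)c(CC=C(C)C)c3)c(=O)oc2c1C`: 2190 nM
- Compound 3 `CC(C)=CCc1cc(C(=O)Nc2cc3ccc(OCCCN(C(C)C)C(C)C)c(C)c3oc2=O)ccc1O`: 1310 nM

Compound 3 cannot be told apart from either of the others: a 1.8-fold higher number from compound 1 to compound 3 (0.27 log units; within the scatter) and a 1.7-fold lower number from compound 2 to compound 3 (0.22 log units; within the scatter) both stay within the scatter. Compound 4 `CC(C)=CCc1cc(C(=O)Nc2cc3ccc(OCCCNC(C)(C)C)c(C)c3oc2=O)ccc1O` changes one group: (tert-butyl)amino in place of diisopropylamino on a saturated chain carbon, three bonds along the chain from an oxygen on an aromatic ring, with (tert-butyl)amino in place of diisopropylamino on a saturated chain carbon, three bonds along the chain from an oxygen on an aromatic ring. Within the data shown here, all the measured steps swap the amine group on this chain, and only a 3.1-fold higher number from compound 1 to compound 2 (0.49 log units; beyond the scatter) goes beyond the scatter, modestly. Among the measured compounds shown here, no measured compound carries (tert-butyl)amino, so this evidence is indirect. No step beyond the scatter is expected, and the estimated step is a 1.1-fold lower number from compound 3 to compound 4 (0.04 log units; within the scatter). The estimate for compound 4 is 1200 nM, with an expected range from 520 nM to 2800 nM.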

Compound 4, half-maximal inhibitory concentration: 950 nM
Compound 4: the middle estimate sits 1.3-fold (0.10 log units) above what was measured, within the range that was stated.
By their numbers in this assay, from the lowest: compounds 1, 4, 3 and 2 (each within the scatter of the next, the first and the last beyond it).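

On this chain, (tert-butyl)amino, with one hydrogen-bond donor where diisopropylamino has none, cannot be told apart from the earlier amines in two comparisons in this assay: there is a 1.4-fold lower number from compound 3 to compound 4 (0.14 log units; within the scatter) and a 1.3-fold higher number from compound 1 to compound 4 (0.13 log units; within the scatter) within the same scatter. Compound 2 now stands apart from a second amine, with a 2.3-fold lower number from compound 2 to compound 4 (0.36 log units; beyond the scatter) as a modest step. Nothing measured here gives a reason for these steps.

Still open, as far as these compounds go, is whether morpholine or a plain primary amine on this chain would give a similar number. A longer chain carrying (tert-butyl)amino is also untested in the compounds shown.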